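Trimming One Methoxy From the Ketone Ring

The compounds below may be only part of what the source reports. "The series", "measured", "known", "first", "only" and "open" are said of these compounds alone.

Measured so far:
compound 1 `COc1cc(-c2cc(/C=C/C(=O)c3ccc(N)cc3)[nH]n2)cc(OC)c1OC`: -91%
compound 2 `COc1cc(-c2cc(/C=C/C(=O)c3ccc(Cl)c(Cl)c3)[nH]n2)cc(OC)c1OC`: -50%
compound 3 `COc1ccc(C(=O)/C=C/c2cc(-c3cc(OC)c(OC)c(OC)c3)n[nH]2)cc1OC`: -86%

These three compounds share one core and differ only in the aromatic ring attached to the carbonyl carbon. They were tested in a functional assay on HCC 2998 cells (Homo sapiens) for cytotoxicity, read by sulforhodamine B assay, with a stated time of 48 h, tested at 100 uM; on this read-out lower numbers stand for a stronger effect and higher numbers for a weaker effect at the one concentration tested. In this assay compound 1 gives -91%, compound 2 gives -50% and compound 3 gives -86%. Compound 3 sits close to compound 1, since the step of a number 5 percentage points higher from compound 1 to compound 3 (within the scatter) stays within the scatter, while the step of a number 36 percentage points lower from compound 2 to compound 3 (beyond the scatter) is large, as is a number 41 percentage points higher from compound 1 to compound 2 (beyond the scatter).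

Compound 4 `COc1ccc(C(=O)/C=C/c2cc(-c3cc(OC)c(OC)c(OC)c3)n[nH]2)cc1` arises from compound 3 through (hydrogen in place of methoxy on an aromatic carbon), the ring on the carbonyl carbon going from 3,4-dimethoxyphenyl to 4-methoxyphenyl. For the measured compounds named here, no measured step removes a single methoxy group from this ring; the measured steps swap whole substituent patterns. The two substitution patterns carrying oxygen or nitrogen groups, in compound 1 and compound 3, sit close together, and only the dichloro pattern of compound 2 stands apart. Keeping one methoxy therefore suggests a small step, a number 6 percentage points higher from compound 3 to compound 4 (within the scatter), expected to lie within the scatter or only slightly toward weaker effect. Compound 4 is estimated at -80%, with a range from -95% to -50%.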

Compound 4, a percentage reported as activity, at one concentration (the size of the read-out at that concentration, not a potency): -82%
Estimate against measurement, compound 4: 2 percentage points above, within the range that was stated.
By their numbers in this assay, from the lowest: compounds 1, 3 and 4 (each within the scatter of the next); then compound 2.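

In this assay, taking a single methoxy off the ring on the carbonyl carbon, which turns 3,4-dimethoxyphenyl into 4-methoxyphenyl, gives a number 4 percentage points higher from compound 3 to compound 4 (within the scatter), so this one group can go without a change that stands out from the scatter. Methoxy in place of amino on that ring likewise gives only a number 9 percentage points higher from compound 1 to compound 4 (within the scatter), while the change from 3,4-dichlorophenyl to 4-methoxyphenyl gives a number 32 percentage points lower from compound 2 to compound 4 (beyond the scatter), which shows that one methoxy alone is enough to keep the large gap to the dichloro ring. Nothing measured here gives a reason for these steps.

The compounds shown leave open whether the ring needs any group at all, since a plain phenyl ring is not among them. A hydroxyl or a single chlorine in place of this methoxy would show how much the choice of group matters.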